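Aryl-alkyne replacement in the series, compound 1 to compound 3

This account rests on a few compounds, and the source may have more. Where it says the series, first, only, none or still open, it means among the compounds named here.

The series shares the core of compound 1 `Cc1cccc(C#Cc2ccc(C(=O)N[C@H](C)C(C)(C)O)nc2)c1` and varies the group on the triple-bonded carbon. Within the data shown here, in an ADME assay on HEK293 cells for agonist activity at metabotropic glutamate receptor 5 (Rattus norvegicus), read by fluorescence and calcium flux (on this read-out lower numbers stand for smaller maximal responses and higher numbers for larger maximal responses), compound 1 gives 20.8% and stands highest of the two numbers measured so far. Compound 2 `C[C@@H](NC(=O)c1ccc(C#Cc2cccc(F)n2)cn1)C(C)(C)O` gives 8.3% in this assay, which makes a number 12.5 percentage points lower from compound 1 to compound 2 (beyond the scatter) for the exchange of 6-fluoropyridin-2-yl in place of 3-methylphenyl on the triple-bonded carbon.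

Compound 3 `C[C@@H](NC(=O)c1ccc(C#Cc2ncccc2F)cn1)C(C)(C)O` is not yet measured. Its change from compound 1 is 3-fluoropyridin-2-yl in place of 3-methylphenyl on a triple-bonded carbon. Among the measured compounds shown here, the only measured step that bears on it is the one from compound 1 to compound 2, where a fluorinated pyridinyl replaced the same 3-methylphenyl at the same place and the response fell by a modest amount beyond the scatter. A similar fall is therefore expected for compound 3, though the position of the fluorine on the pyridinyl differs, so the size is uncertain. The expected step is a number 10.8 percentage points lower from compound 1 to compound 3 (beyond the scatter). Compound 3 is estimated at 10% in this assay, with a range from 2% to 22%.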

Compound 3, largest response reached (reported as efficacy), in percent of the reference or control that the assay uses: 29.2%
The estimate for compound 3 lay 19.2 percentage points below the measured number, outside the stated range (above it).
By their numbers in this assay, from the lowest: compound 2; then compounds 1 and 3 (each within the scatter of the next).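

In this assay, 3-fluoropyridin-2-yl in place of 3-methylphenyl on the triple-bonded carbon gives a number 8.4 percentage points higher from compound 1 to compound 3 (within the scatter) and shows that a fluorinated pyridinyl at this place does not by itself bring the fall seen with compound 2. The exchange of 6-fluoropyridin-2-yl for 3-fluoropyridin-2-yl gives a number 20.9 percentage points higher from compound 2 to compound 3 (beyond the scatter) and shows that, across these three compounds, the response at this place depends on which fluorinated pyridinyl is present and not merely on having one. No measurement at hand accounts for the difference between these two groups.

The compounds shown leave open whether the fluorine or the ring nitrogen of the 3-fluoropyridin-2-yl group governs the response, a question that pyridin-2-yl without fluorine or 3-chloropyridin-2-yl on the triple-bonded carbon would bear on. They also leave open whether the same ranking of these aryl groups would hold if the group on the amide of the shared core were a shorter chain or carried an amine.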